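A few compounds are considered here, and "the series" means these few. Any claim that something is new, unique, unknown or untested is made for them only; others in the source may bear on it.

Compound 1 `CN1CCCC[C@H]1[C@H]1COC(c2ccccc2)(c2ccccc2)O1` is the parent of a small set measured in a functional assay (brain) for displacement of a labelled ligand, with Rattus norvegicus as the target (on this read-out lower numbers stand for stronger inhibition and higher numbers for weaker inhibition), where compound 1 gives 4400 nM. Compound 2 `CCCN1CCCC[C@H]1[C@H]1COC(c2ccccc2)(c2ccccc2)O1` carries ethyl in place of hydrogen on a saturated chain carbon bound to an amine nitrogen in a ring and gives 6800 nM, a change of a 1.5-fold higher number from compound 1 to compound 2 (0.19 log units; within the scatter). Compound 3 `c1ccc(CN2CCCC[C@H]2[C@H]2COC(c3ccccc3)(c3ccccc3)O2)cc1` carries phenyl at the same carbon and gives 10100 nM, a change of a 2.3-fold higher number from compound 1 to compound 3 (0.36 log units; beyond the scatter); between compound 2 and compound 3 the step is a 1.5-fold higher number from compound 2 to compound 3 (0.17 log units; within the scatter). Compound 1 thus has the lowest number of the three, though its gap to compound 2 lies within the scatter.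

Compound 4 `NC[C@H]1COC(c2ccccc2)(c2ccccc2)O1` departs from compound 1 differently: aminomethyl in place of 1-methylpiperidin-2-yl on a saturated ring carbon. The measured steps all concern what sits on the chain carbon attached to the ring amine nitrogen and were small; none of them removes the ring itself, so they bear on this change only loosely. Because the enlargements in a 2.3-fold higher number from compound 1 to compound 3 (0.36 log units; beyond the scatter) already moved the number upward, and because the change to compound 4 is far larger, the expectation is a step of a 3.4-fold higher number from compound 1 to compound 4 (0.53 log units; beyond the scatter) toward weaker inhibition. Compound 4 is therefore expected to give about 15000 nM, with a range from 3000 nM to 70000 nM.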

Compound 4, inhibition constant: 1400 nM
Compound 4: the middle estimate sits 11-fold (1.03 log units) above what was measured, and the stated range ends above it.
By their numbers in this assay, from the lowest: compound 4; then compounds 1, 2 and 3 (each within the scatter of the next, the first and the last beyond it).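

For the compounds shown here, measured in this assay, the exchange of 1-methylpiperidin-2-yl for aminomethyl on the saturated ring carbon gives a 3.1-fold lower number from compound 1 to compound 4 (0.50 log units; beyond the scatter), the only step in this set that lowers the number beyond the scatter. The earlier compounds shown here varied only what sits on the chain carbon bound to the ring amine nitrogen and always kept the six-membered non-aromatic ring, whereas compound 4 shows that this ring and its defined stereocentre are not required for inhibition at this level, and that the much smaller aminomethyl is tolerated on the shared core. No measurement is available to explain this shift.

The change alters several things at once, so the compounds shown leave open whether the lower number goes with losing the ring, with losing the methyl on the nitrogen, or with both, a question that piperidin-2-yl or methylaminomethyl at the same carbon would help to separate. They also leave open how far the chain can vary here, for instance whether a longer chain such as 2-aminoethyl would keep the lower number of compound 4.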